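A few compounds are considered here, and "the series" means these few. Any claim that something is new, unique, unknown or untested is made for them only; others in the source may bear on it.

In a functional assay on MDA-MB-231 cells (Homo sapiens) for antiproliferative activity, read by MTT assay, with a stated time of 48 h (on this read-out higher numbers stand for weaker inhibition and lower numbers for stronger inhibition), the measured compounds read as follows.

Compound 1 `C=CS(=O)(=O)N1CCN(c2ncnc3sc(-c4ccccc4)cc23)CC1` gives 54200 nM
Compound 2 `C=CS(=O)(=O)N1CCN(c2ncnc3ccc(-c4ccccc4)cc23)CC1` gives 47900 nM
Compound 3 `C=CS(=O)(=O)N1CCN(c2ncnc3sc(-c4ccc(C(F)(F)F)cc4)cc23)CC1` gives 6410 nM

Compound 3 has the lowest number of the three, and its distance to each of the other two lies beyond the usual scatter. Compound 4 `C=CS(=O)(=O)N1CCN(c2ncnc3sc(-c4ccc(OC)cc4)cc23)CC1` keeps all of compound 3 except one group, with methoxy in place of trifluoromethyl on an aromatic carbon. The group sits on a six-membered aromatic ring of carbon only, para to a large group.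

Going by the values given here, one measured step bears on this spot, an 8.5-fold lower number from compound 1 to compound 3 (0.93 log units; beyond the scatter) for trifluoromethyl in place of hydrogen on an aromatic carbon. That step is modest but beyond the scatter. Among the compounds with values here, no methoxy compound has been measured, so it frames the question without answering it. Compound 1, with only hydrogen at this spot, gives 54200 nM and serves as a rough upper reference. Methoxy is therefore expected to keep only part of the gain seen with trifluoromethyl. The expected move is a 3.1-fold higher number from compound 3 to compound 4 (0.49 log units; beyond the scatter) in this assay and points toward a higher number. For compound 4 the estimated value is 20000 nM and the expected range runs from 7000 nM to 55000 nM as a deliberately wide span.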

Compound 4, half-maximal inhibitory concentration: 29900 nM
The estimate for compound 4 lay 1.5-fold (0.17 log units) below the measured number, within the range that was stated.
By their numbers in this assay, from the lowest: compound 3; then compounds 4, 2 and 1 (each within the scatter of the next).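

In this assay the exchange of trifluoromethyl for methoxy gives a 4.7-fold higher number from compound 3 to compound 4 (0.67 log units; beyond the scatter) and so shows that the gain seen with trifluoromethyl does not come with either group placed on this aromatic carbon, para to a large group. Putting methoxy in place of hydrogen gives a 1.8-fold lower number from compound 1 to compound 4 (0.26 log units; within the scatter) and so, at this spot, methoxy cannot be told apart from plain hydrogen, while trifluoromethyl stands clear of both beyond the usual scatter. The position therefore responds to which group sits on it, but nothing available here explains why these two groups part ways.

On these data alone, two groups and hydrogen are too few to show what the position favours, so it remains open whether a chlorine atom, a nitrile or a carboxylic acid on the same carbon would match compound 3 or stay level with compound 1 and compound 4. As far as these compounds go, it is also open whether trifluoromethyl would bring a similar gain on the core of compound 2, which carries only hydrogen at the matching spot on its phenyl ring.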